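The source may hold more compounds than are shown below. What is called first, only, known or untested is meant among the compounds shown, and "the series" means these compounds.

Measured compounds:
compound 1, `C/C(=N\NC(=O)c1ccccc1O)c1c(C(=O)O)noc1C`: 52%
compound 2, `C/C(=N\NC(=O)c1cccc2ccccc12)c1c(C(=O)O)noc1C`: 68%
compound 3, `COc1ccc(C(=O)N/N=C(\C)c2c(C(=O)O)noc2C)cc1`: 68%

All three were run in an assay on SNB-19 cells for inhibition of cystine/glutamate transporter (Homo sapiens), read by scintillation counting, with a stated time of 5 min, tested at 500 uM; on this read-out higher numbers stand for more inhibition at the one concentration tested (going by the name of the read-out) and lower numbers for less inhibition. Within this set compound 3 stands level with compound 2 at the digits given, and the two together are the highest of the three numbers; the difference between them is within the scatter. Compound 1 lies furthest from compound 3, its value being lower by a margin beyond the scatter. No pair of these compounds differs in a single place, so no single-change step is available from the measured set.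

Compound 4, `C/C(=N\NC(=O)c1ccccc1)c1c(C(=O)O)noc1C`, has not yet been measured in this assay. It differs from compound 3 as follows: hydrogen in place of methoxy on an aromatic carbon. Since nothing in the measured set isolates this change, the expectation for compound 4 rests only on compound 3 and on the spread of the three measured values. For this assay a small step downward from compound 3 is expected, of a size that may well stay within the scatter; a step upward beyond the scatter is not expected.

Compound 4 is estimated at 60% in this assay, with a range from 42% to 76%. This estimate means a step of a number 8 percentage points lower from compound 3 to compound 4 (within the scatter), which is expected rather than known.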

Compound 4, a percentage reported as inhibition, at one concentration (the size of the read-out at that concentration, not a potency): 83%
Estimate against measurement, compound 4: 23 percentage points below; the whole stated range lies below it.
By their numbers in this assay, from the lowest: compound 1; then compounds 2 and 3 (each within the scatter of the next); then compound 4.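

Working from compound 4 as the reference, the methoxy group is not needed on this aromatic carbon, para to a large group, for the read-out in this assay: hydrogen in place of methoxy gives a number 15 percentage points higher from compound 3 to compound 4 (beyond the scatter) and so counts as a real gain in this single pair. The second pair points the same way, since losing the hydroxy group from the ring gives a number 31 percentage points higher from compound 1 to compound 4 (beyond the scatter) and the substituent-free ring again carries the higher number. Across these two pairs, neither oxygen-linked group matches plain hydrogen, which the three earlier compounds could not show, but nothing at hand explains the direction of either step.

Still open, from the compounds shown here alone, is whether any group on this carbon can match or exceed hydrogen, with a fluorine atom, an amine, a carboxylic acid or a longer chain such as ethoxy as the obvious probes, and whether the methoxy result carries over to other places on the ring. Each number also comes from one concentration, so how these steps translate into potency remains unsettled.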